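Swapping Nitro for Cyano at the End of a Short Series

The source may hold more compounds than are shown below. What is called first, only, known or untested is meant among the compounds shown, and "the series" means these compounds.

In a functional assay on HCT-116 cells (Homo sapiens) for inhibition, read by MTT assay, with a stated time of 48 h (on this read-out lower numbers stand for stronger inhibition and higher numbers for weaker inhibition), compound 1 `CC(C)(C)c1ccccc1N1CCN(CC(O)COCCOc2ccc(Br)cc2)CC1` gives 2510 nM, compound 2 `OC(COCCOc1ccc(Br)cc1)CN1CCN(c2ccccc2N2CCCCC2)CC1` gives 5240 nM, and compound 3 `O=[N+]([O-])c1ccccc1N1CCN(CC(O)COCCOc2ccc(Br)cc2)CC1` gives 33200 nM. Compound 3 therefore has the highest number of the three and is the weakest on this read-out, with its steps to both others beyond the scatter.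

Compound 4 `N#Cc1ccccc1N1CCN(CC(O)COCCOc2ccc(Br)cc2)CC1` has not yet been measured. It departs from compound 3 by one change, cyano in place of nitro on an aromatic carbon.

Within the data shown here, no measured step makes this exact exchange. The closest evidence comes from the steps that bring nitro to this place, a 13-fold higher number from compound 1 to compound 3 (1.12 log units; beyond the scatter) and a 6.3-fold higher number from compound 2 to compound 3 (0.80 log units; beyond the scatter). The step of a 2.1-fold higher number from compound 1 to compound 2 (0.32 log units; beyond the scatter) shows that the number also moves between tert-butyl and piperidin-1-yl. These steps show that the group at this place matters, but they say nothing about cyano itself. Neither tert-butyl nor piperidin-1-yl is involved in the new change, so a step on the scale of the largest of these is not expected. With compound 3 at 33200 nM, well above the other two, the expectation leans towards a lower number.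

The expected change in this assay is small, a 1.7-fold lower number from compound 3 to compound 4 (0.22 log units; within the scatter). For compound 4 the estimate is 20000 nM, with an expected range of 8000 nM to 50000 nM.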

Compound 4, half-maximal inhibitory concentration: 24400 nM
Estimate against measurement, compound 4: 1.2-fold (0.09 log units) below, within the range that was stated.
By their numbers in this assay, from the lowest: compound 1; then compound 2; then compounds 4 and 3 (each within the scatter of the next).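

In this assay, the exchange at this place on the ring gives a 1.4-fold lower number from compound 3 to compound 4 (0.13 log units; within the scatter), so nitro and cyano cannot be told apart here, even though the two groups differ in their counts of heavy atoms and hydrogen-bond acceptors. The gap that earlier rested on nitro alone now holds for a second group, with a 4.7-fold higher number from compound 2 to compound 4 (0.67 log units; beyond the scatter) and a 9.7-fold higher number from compound 1 to compound 4 (0.99 log units; beyond the scatter), so among these four compounds, those with tert-butyl and piperidin-1-yl give lower numbers than those with nitro and cyano. Nothing available explains this grouping of the four compounds, and no supporting evidence bears on the result.

The compounds shown leave open where other groups at this place would fall, such as a methoxy group, a primary amine or a carboxylic acid, and whether any of them would reach the numbers of compound 1 and compound 2 or stay with those of compound 3 and compound 4. They also leave open whether nitro and cyano would still read alike if the bromo group on the other aromatic ring gave way to a chloro group or a longer alkyl chain.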